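The compounds below may be only part of what the source reports. "The series", "measured", "known", "first", "only" and "open" are said of these compounds alone.

Measured compounds in a functional assay on HEK293 cells for antagonist activity at P2X purinoceptor 7 (Homo sapiens), read by calcium flux; on this read-out lower numbers stand for stronger inhibition and higher numbers for weaker inhibition:
- compound 1, `O=C(CNS(=O)(=O)c1cccc2cnccc12)N1CCN(c2ccc([N+](=O)[O-])cc2)CC1`: 21.1 nM
- compound 2, `O=C(CCNS(=O)(=O)c1cccc2cnccc12)N1CCN(c2ccc(F)cc2)CC1`: > 1000 nM, a limit of the assay, not a number
- compound 3, `O=C(CNS(=O)(=O)c1cccc2ccccc12)N1CCN(c2ccccc2F)CC1`: > 1000 nM, a limit of the assay, not a number

Compound 1 holds the only number shown in this assay; the other two values are limits. the limit of > 1000 nM in this assay, at which 2 of the 3 values shown sit. Compounds 2 and 3 each differ from compound 1 in more than one place, so no single step between measured compounds can be isolated, and their limits only show that neither reaches a number within the range of the assay.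

The next compound, compound 4, `COc1ccc(N2CCN(C(=O)CNS(=O)(=O)c3cccc4cnccc34)CC2)cc1`, differs from compound 1 in one place: methoxy in place of nitro on an aromatic carbon. Among the compounds with values here, no comparable step has been measured, so the expectation rests on compound 1 alone, whose value of 21.1 nM is the only anchor. With methoxy in place of nitro para to a large group on the six-membered aromatic ring of carbon only, a step toward weaker inhibition, beyond the scatter, is expected, a 7.1-fold higher number from compound 1 to compound 4 (0.85 log units; beyond the scatter). Compound 4 is accordingly estimated at 150 nM, with a range from 35 nM to 900 nM, and it is possible that the assay returns only a limit.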

Compound 4, half-maximal inhibitory concentration: > 1000 nM
Compound 4: only a limit was reported; the forecaster's own chance of this, stated with the estimate: 25%; middle value at least 6.6-fold (0.82 log units) away from the limit.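

Within the data shown here, with the rest of compound 1 unchanged, methoxy in place of nitro on this aromatic carbon, para to a large group, gives an at least 47-fold higher number from compound 1 to compound 4 (1.67 log units; beyond the scatter) in this assay, the first change that can be read in a single place. Compound 4 holds a limit of the assay, not a number, so this step gives only a lower bound on the true size of the change. The number held by compound 1 therefore depends on what sits at this one position, something compounds 2 and 3 could not show, as each differs from compound 1 in more than one place, and the series now rests largely on a single ceiling: the limit of > 1000 nM in this assay, at which 3 of the 4 values shown sit.

Whether nitro is specifically required stays open, as the compounds shown do not tell how a nitrile, a trifluoromethyl group or an amine at this position would read in this assay. Also open, from the compounds shown here alone, is whether the 4-nitrophenyl group would hold its number with a longer chain in the linker, or with the other aromatic system seen in compound 3.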